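A few compounds are considered here, and "the series" means these few. Any claim that something is new, unique, unknown or untested is made for them only; others in the source may bear on it.

Measured so far in an assay on isolated protein for displacement of a labelled ligand from metabotropic glutamate receptor 5 (Homo sapiens), with a stated time of 60 min, tested at 1 uM; a higher number here means more inhibition at the concentration tested (going by the name of the read-out), a lower number less inhibition:
Compound 1 `CC1CCN(c2c(S(=O)(=O)c3ccc(Cl)cc3)cnc3cc(F)ccc23)CC1` gives 90%.
Compound 2 `COc1ccc(S(=O)(=O)c2cnc3cc(F)ccc3c2N2CCC(C)CC2)cc1` gives 90%.
Compound 3 `CC1CCN(c2c(S(=O)(=O)c3ccccc3)cnc3ccccc23)CC1` gives 89.2%.

Compound 3 holds the lowest of the three numbers, but both compound 1 and compound 2 lie within the scatter of it, so the three are indistinguishable. Compound 4 `CC1CCN(c2c(S(=O)(=O)c3ccccc3)cnc3cc(F)ccc23)CC1` differs from compound 3 by fluoro in place of hydrogen on an aromatic carbon. Within the data shown here, no measured step covers this change directly. Among the measured compounds shown here, the one measured step, no change at the digits printed from compound 1 to compound 2 (within the scatter), concerns another position and stayed within the scatter, so the number stayed level across that change. Compound 1 and compound 2 already carry the fluoro and sit within the scatter of compound 3. Compound 4 is therefore expected to show a number 0.8 percentage points higher from compound 3 to compound 4 (within the scatter), a step of no size beyond the scatter. The estimate for compound 4 is 90%, within 80% to 97%.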

Compound 4, a percentage reported as inhibition, at one concentration (the size of the read-out at that concentration, not a potency): 87%
For compound 4 the middle estimate is 3 percentage points above the measured one, within the range that was stated.
By their numbers in this assay, from the lowest: compounds 4, 3, 1 and 2 (each within the scatter of the next).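

In this assay the fluoro on the aromatic carbon para to a fused ring now has a direct measured step, a number 2.2 percentage points lower from compound 3 to compound 4 (within the scatter), so adding it to the unsubstituted core leaves the number level. With that fluoro in place, hydrogen in place of methoxy gives a number 3 percentage points lower from compound 2 to compound 4 (within the scatter) and hydrogen in place of chloro gives a number 3 percentage points lower from compound 1 to compound 4 (within the scatter), so neither group stands apart from hydrogen here. These single-concentration numbers leave open whether the four compounds differ in potency, and whether an amine or a carboxylic acid in place of the chloro or methoxy would shift the number beyond the scatter. No evidence is available that bears on these results.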